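Bromo to methyl on the benzyl ether ring

The source may report more compounds than this note shows. Statements on the series, on what has been measured and on what is new or still open speak of the compounds shown alone.

Compound 1 `O=c1ccoc2ccc(OCc3cccc(Br)c3)cc12` and compound 2 `O=c1ccoc2ccc(OCc3ccc(Br)cc3)cc12` are built from the same atoms joined differently; the difference between the two cores is not broken down here. In an assay on microsomes for inhibition of Amine oxidase [flavin-containing] A (Homo sapiens), read by fluorescence and spectrophotometry, with a stated time of 20 min (a lower number here means a stronger inhibitor, a higher number a weaker inhibitor), compound 1 gives 386 nM. In this assay compound 2 gives 95 nM, the lowest of the three measured numbers. Compound 3 `Cc1cccc(COc2ccc3occc(=O)c3c2)c1` follows from compound 1 by methyl in place of bromo on an aromatic carbon. In this assay compound 3 gives 1130 nM, a step of a 2.9-fold higher number from compound 1 to compound 3 (0.47 log units; beyond the scatter).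

Compound 4 `Cc1ccc(COc2ccc3occc(=O)c3c2)cc1` has not been measured. It follows from compound 2 by methyl in place of bromo on an aromatic carbon. This is the same kind of change as that from compound 1 to compound 3, though not the same: in the first pair the group sits meta to a large group, in the second para to a large group. Only one measured case of this change exists, so the expectation rests on it alone. Compound 4 is expected to move by a 2.9-fold higher number from compound 2 to compound 4 (0.47 log units; beyond the scatter) in this assay, a step similar in size to the one seen earlier. For compound 4 the estimate in this assay is 280 nM, with a range from 120 nM to 650 nM.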

Compound 4, half-maximal inhibitory concentration: 3490 nM
The estimate for compound 4 lay 12-fold (1.10 log units) below the measured number; the whole stated range lies below it.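

On the core of compound 2, methyl in place of bromo on an aromatic carbon, para to a large group, gives a 37-fold higher number from compound 2 to compound 4 (1.57 log units; beyond the scatter) in this assay. The direction of this change carries from one core to the other, but its size does not: the same change on two cores in this assay, a 2.9-fold higher number (0.47 log units; beyond the scatter) from compound 1 to compound 3 and a 37-fold higher number (1.57 log units; beyond the scatter) from compound 2 to compound 4, 13-fold (1.10 log units) apart, beyond the scatter of two such steps

These two pairs do not show what sets the gap between the steps, and they give no basis for predicting the size of the step on a further core; the step from one pair should not be carried over as a number.

The compounds shown leave open how chloro, methoxy, nitrile or an amine would read in this assay at the same place on either core, and so whether the gap is particular to bromo and methyl. They also leave open what a longer chain in place of the benzyl ether link would do to the numbers on these cores.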